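A few compounds are considered here, and "the series" means these few. Any claim that something is new, unique, unknown or untested is made for them only; others in the source may bear on it.

Compound 1 `CC(=O)/C=C1\C[C@H]2SC(C)(C)[C@H](C(=O)OC(c3ccccc3)c3ccccc3)N2C1=O` gives, in a functional assay on NCI-H1299 cells (Homo sapiens) for cytotoxicity, read by MTT assay, with a stated time of 48 h (a lower number here means a stronger inhibitor, a higher number a weaker inhibitor), > 100000 nM.
Compound 2 `CCOC(=O)/C=C1/C(=O)N2[C@@H]1SC(C)(C)[C@@H]2C(=O)OC(c1ccccc1)c1ccccc1` gives, in this assay, 15000 nM.
Compound 3 `CC(=O)/C=C1/C(=O)N2[C@@H]1SC(C)(C)[C@@H]2C(=O)OC(c1ccccc1)c1ccccc1` gives, in this assay, 24200 nM.

Of the compounds shown here, three built on one shared core have so far been tested in this assay. For compound 1 the result is only a limit, > 100000 nM, and no number is known for it (the limit of > 100000 nM in this assay, at which 1 of the 3 values shown sits). Among the measured compounds shown here, compound 2 and compound 3 both give numbers, and the step between them, a 1.6-fold higher number from compound 2 to compound 3 (0.21 log units; within the scatter), is the only measured change. Of the two numbers, compound 3 has the higher one, but its gap to compound 2 is within the scatter, so no order between these two compounds can be claimed.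

Compound 4 `CC1(C)S[C@@H]2/C(=C\C(=O)OCc3ccccc3)C(=O)N2[C@H]1C(=O)OC(c1ccccc1)c1ccccc1` has not yet been measured. It differs from compound 3 in one place: benzyloxy in place of methyl on a carbonyl carbon. For the measured compounds named here, the one measured step that touches this same carbonyl carbon, a 1.6-fold higher number from compound 2 to compound 3 (0.21 log units; within the scatter), swapped methyl for ethoxy and produced no difference beyond the scatter. Nothing measured speaks to a benzyloxy group at this place. On that basis, the step from compound 3 to compound 4 is expected to be small, a 1.6-fold lower number from compound 3 to compound 4 (0.21 log units; within the scatter), in no clear direction. The estimate for compound 4 in this assay is 15000 nM, with a range from 4000 nM to 50000 nM.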

Compound 4, half-maximal inhibitory concentration: 9400 nM
For compound 4 the middle estimate is 1.6-fold (0.20 log units) above the measured one; the measured number falls inside the stated range.
By their numbers in this assay, from the lowest: compounds 4, 2 and 3 (each within the scatter of the next, the first and the last beyond it). At a limit, above all of these: compound 1.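

At the carbonyl carbon whose other neighbour is the double-bonded chain carbon, the earlier compounds had shown only a swap of ethoxy and methyl that stayed within the scatter, whereas benzyloxy in place of methyl gives the first step at this place that goes beyond it, though a modest one, in this assay: a 2.6-fold lower number from compound 3 to compound 4 (0.41 log units; beyond the scatter). The other route to the same compound, phenyl in place of methyl on a saturated chain carbon bound to an oxygen next to a carbonyl group, stays within the scatter, a 1.6-fold lower number from compound 2 to compound 4 (0.20 log units; within the scatter), so compound 2 cannot be ordered against compound 4, and only the change from acetyl to benzyloxycarbonyl separates two compounds at this position. Nothing measured among the data shown accounts for that separation.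

Open, going by these compounds, is whether the gain in this assay needs the aromatic ring at all, since a longer chain, such as butoxy, on this carbonyl carbon would be needed to tell ring from length. Also open, on these data alone, is how this position responds to a carboxylic acid or an amine-derived amide there, or to a phenoxy group set directly in place of benzyloxy.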